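A few compounds are considered here, and "the series" means these few. Any claim that something is new, unique, unknown or untested is made for them only; others in the source may bear on it.

Measured so far:
Compound 1, `CS(=O)(=O)c1ccc(C(=O)NCCCC(=O)N2Cc3ccccc3C2)cc1[N+](=O)[O-]`: in an assay on isolated protein for inhibition of thyroid hormone receptor alpha (Homo sapiens), read by fluorescence polarization (a higher number here means a weaker inhibitor, a lower number a stronger inhibitor), compound 1 gives > 60000 nM, which is a limit of the assay and not a number.
Compound 2, `CS(=O)(=O)c1ccc(C(=O)NCCC(=O)N2CCc3ccccc3C2)cc1[N+](=O)[O-]`: in this assay compound 2 gives > 60000 nM, likewise a limit and not a number.

Compound 1 therefore stands at the edge of what this assay can report, the point where both values shown sit (the limit of > 60000 nM in this assay, at which 2 of the 2 values shown sit). Within the data shown here, no step between measured compounds exists, so nothing is known of how any change moves the read-out. Compound 3 `CC1CCN(C(=O)CCCNC(=O)c2ccc(S(C)(=O)=O)c([N+](=O)[O-])c2)CC1` has not been measured. It differs from compound 1 in one place: a group of 7 heavy atoms (6 carbon, 1 nitrogen; one six-membered non-aromatic ring with 1 hetero atom) in place of a group of 9 heavy atoms (8 carbon, 1 nitrogen; one five-membered non-aromatic ring with 1 hetero atom, one six-membered aromatic ring of carbon only), on a carbonyl carbon. Since both values shown sit at the limit (the limit of > 60000 nM in this assay, at which 2 of the 2 values shown sit), the step in this assay is expected to be none beyond the scatter, and the expected step is a step that the limit leaves unreadable from compound 1 to compound 3. Compound 3 is expected to give about 90000 nM in this assay, within 30000 nM to 300000 nM, most probably reported again only as a limit.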

Compound 3, half-maximal inhibitory concentration: > 60000 nM
Compound 3: only a limit was reported; the forecaster's own chance of this, stated with the estimate: 85%; the middle value is on the limit's open side.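

In this assay compound 3 gives > 60000 nM, a limit and not a number, so no step from compound 1 to compound 3 can be read: the limit of > 60000 nM in this assay, at which 3 of the 3 values shown sit.

The compounds shown leave open whether any group on the carbonyl carbon gives a measurable value in this assay.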